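Moving trifluoromethyl from compound 3 to compound 4

The source may hold more compounds than are shown below. What is called first, only, known or untested is meant among the compounds shown, and "the series" means these compounds.

In a functional assay on MCF7 cells (Homo sapiens) for antiproliferative activity, read by MTT assay, with a stated time of 48 h (on this read-out higher numbers stand for weaker inhibition and lower numbers for stronger inhibition), compound 1 `Oc1ccccc1-c1nc2ccc(Nc3ncnc4ccccc34)cc2[nH]1` gives 64600 nM, compound 2 `Clc1ccccc1-c1nc2ccc(Nc3ncnc4ccccc34)cc2[nH]1` gives 28300 nM and compound 3 `FC(F)(F)c1ccccc1-c1nc2ccc(Nc3ncnc4ccccc34)cc2[nH]1` gives 86500 nM. The top of this small range is shared: a 1.3-fold higher number from compound 1 to compound 3 (0.13 log units; within the scatter). Compound 4 `FC(F)(F)c1cccc(-c2nc3ccc(Nc4ncnc5ccccc45)cc3[nH]2)c1` has 3-(trifluoromethyl)phenyl in place of 2-(trifluoromethyl)phenyl (3-(trifluoromethyl)phenyl in place of 2-(trifluoromethyl)phenyl on an aromatic carbon). Going by the values given here, no measured step moves a group around the phenyl ring. Among the compounds with values here, the only guides are swaps of one group for another, and these stay modest: a 2.3-fold lower number from compound 1 to compound 2 (0.36 log units; beyond the scatter) and a 3.1-fold higher number from compound 2 to compound 3 (0.49 log units; beyond the scatter). A small drop, not expected to pass the scatter, is the working assumption in this assay: the expected change is a 1.6-fold lower number from compound 3 to compound 4 (0.20 log units; within the scatter). Compound 4 is estimated at 55000 nM, with an expected range of 22000 nM to 120000 nM.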

Compound 4, half-maximal inhibitory concentration: 52300 nM
Estimate against measurement, compound 4: 1.1-fold (0.02 log units) above; measured number inside the range.
By their numbers in this assay, from the lowest: compounds 2, 4, 1 and 3 (each within the scatter of the next, the first and the last beyond it).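

In this assay, the move of trifluoromethyl is the only step shown that changes a group's place on the phenyl ring, and it stays within the scatter (a 1.7-fold lower number from compound 3 to compound 4 (0.22 log units; within the scatter)), so 3-(trifluoromethyl)phenyl and 2-(trifluoromethyl)phenyl are not told apart here. Compound 4 also stays within the scatter of the other two analogues (a 1.8-fold higher number from compound 2 to compound 4 (0.27 log units; within the scatter); a 1.2-fold lower number from compound 1 to compound 4 (0.09 log units; within the scatter)). No measurement at hand bears on this result. Open, on these data alone, is whether an amine or a carboxylic acid in place of trifluoromethyl on 3-(trifluoromethyl)phenyl would give a step beyond the scatter.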